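A few compounds are considered here, and "the series" means these few. Any claim that something is new, unique, unknown or untested is made for them only; others in the source may bear on it.

Measured compounds:
compound 1 `Cn1cnnc1-c1cc(Oc2ccc(NC(=O)Nc3cccc(C(F)(F)F)c3)cc2F)ccn1` — 3020 nM
compound 2 `CN(C)CCn1cnnc1-c1cc(Oc2ccc(NC(=O)Nc3ccccc3C(F)(F)F)cc2F)ccn1` — 5860 nM

In a functional assay on HT-29 cells (Homo sapiens) for antiproliferative activity, read by MTT assay, with a stated time of 72 h (a higher number here means a weaker inhibitor, a lower number a stronger inhibitor), compound 1 gives 3020 nM. For the measured compounds named here, compound 2 holds the higher of the two numbers, at 5860 nM, but its only neighbour, compound 1, lies within the scatter of it, so the two cannot be ordered and no step between them is counted.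

Compound 3 `CN(C)CCn1cnnc1-c1cc(Oc2ccc(NC(=O)Nc3ccc(Cl)cc3Cl)cc2F)ccn1` has not been measured in this assay. It differs from compound 2 in one place: 2,4-dichlorophenyl in place of 2-(trifluoromethyl)phenyl on an amide-type nitrogen. Going by the values given here, no measured pair shows this exchange at the amide-type nitrogen, so the size of the step cannot be read from any data here. With both measured compounds sitting in the same range and nothing pointing either way, the expected step is a 1.2-fold lower number from compound 2 to compound 3 (0.07 log units; within the scatter), nothing beyond the scatter. Compound 3 is therefore estimated at 5000 nM, with a range from 1500 nM to 16000 nM.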

Compound 3, half-maximal inhibitory concentration: 1890 nM
Compound 3: the middle estimate sits 2.6-fold (0.42 log units) above what was measured; the range from low to high includes it.
By their numbers in this assay, from the lowest: compounds 3, 1 and 2 (each within the scatter of the next, the first and the last beyond it).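

For the compounds shown here, the aryl group on the amide-type nitrogen is a place where this assay responds: 2,4-dichlorophenyl in place of 2-(trifluoromethyl)phenyl gives a 3.1-fold lower number from compound 2 to compound 3 (0.49 log units; beyond the scatter), the first step that stands beyond the scatter. The step is modest and rests on a single pair, with the rest of the structure held constant, so it describes this one exchange and not a trend for the position. Nothing measured here bears on what in the exchange produces the step.

Still open, from the compounds shown here alone, is how other groups on this nitrogen compare, such as a 4-methoxyphenyl or a 4-fluorophenyl. It is also unknown whether 2,4-dichlorophenyl gives a step of similar size when the dimethylamino end of the chain is replaced by a morpholine.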